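The source may report more compounds than this note shows. Statements on the series, on what has been measured and on what is new or still open speak of the compounds shown alone.

Of the compounds shown here, three of a shared core have been measured in an assay on membranes from HEK293 cells for displacement of a labelled ligand from Type-2 angiotensin II receptor (Homo sapiens), read by radioligand binding; on this read-out lower numbers stand for stronger inhibition and higher numbers for weaker inhibition. Compound 1, `CCCc1ccc(S(=O)(=O)NC(=O)OCCC(F)(F)C(F)(F)F)c(-c2ccc(Cn3c(C(C)(C)C)nc4ccccc43)cc2)c1`, gives 6 nM in this assay. Compound 2, `CCCCOC(=O)NS(=O)(=O)c1ccc(CCC)cc1-c1ccc(Cn2c(CC(C)C)nc3ccccc32)cc1`, gives 19 nM in this assay. Compound 3, `CCCCOC(=O)NS(=O)(=O)c1ccc(CCC)cc1-c1cc(F)c(Cn2c(C(C)(C)C)nc3ccccc32)c(F)c1`, gives 11 nM in this assay. Among these three numbers compound 3 stands second highest, and its gaps to both neighbours fall within the usual scatter of repeated measurements, so the three compounds cannot be told apart on potency from these values alone.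

The next compound, compound 4, `CCCc1ccc(S(=O)(=O)NC(=O)OCCCC(F)(F)F)c(-c2cc(F)c(Cn3c(C(C)(C)C)nc4ccccc43)c(F)c2)c1`, has not yet been measured. It differs from compound 3 in one place: trifluoromethyl in place of methyl on a saturated chain carbon, three bonds along the chain from an oxygen next to a carbonyl group. Among the compounds with values here, no measured pair in this set shows exactly this change, so there is no directly comparable step to lean on. Compound 1 does carry a more heavily fluorinated chain at this end of the molecule and gives 6 nM, but it also differs from compound 3 elsewhere, so its value can only hint that fluorine on this chain is tolerated.

On that basis compound 4 is expected to stay close to compound 3, with a step of a 1.4-fold lower number from compound 3 to compound 4 (0.14 log units; within the scatter) that would not clearly exceed the scatter. The estimate for compound 4 is 8 nM, with a likely range from 3 nM to 20 nM.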

Compound 4, inhibition constant: 12 nM
Compound 4: middle estimate off by 1.5-fold (0.18 log units), on the low side, and the stated range covers the measured number.
By their numbers in this assay, from the lowest: compounds 1, 3, 4 and 2 (each within the scatter of the next, the first and the last beyond it).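

Within the data shown here, this is the first step in the set that changes only one place, and in this assay it reads a 1.1-fold higher number from compound 3 to compound 4 (0.04 log units; within the scatter). The change is trifluoromethyl in place of methyl on a saturated chain carbon, three bonds along the chain from an oxygen next to a carbonyl group, which can also be read as butyl to 4,4,4-trifluorobutyl. Four heavy atoms, three of them fluorine, thus stand where one stood, and on this core the two groups cannot be told apart on this read-out, though nothing in the data shown gives a reason for this result.

What the compounds shown leave open is how far this freedom at the chain end extends: a hydroxyl group, an amine or a carboxylic acid on this carbon, or a longer chain such as hexyl, could give a similar number or a very different one. A single step on a single core also leaves open whether trifluoromethyl in place of methyl would give the same result on another core.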